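A Methyl Added on the Chain of Compound 1

The source may hold more compounds than are shown below. What is called first, only, known or untested is meant among the compounds shown, and "the series" means these compounds.

Compound 1 `CCn1c(=O)ccn(C2OC(Cn3cc(COC(=O)Cn4cnc5c4c(=O)n(C)c(=O)n5C)nn3)C(O)C2O)c1=O`: 4890 nM
Compound 2 `Cn1c(=O)c2c(ncn2CC(=O)NCc2cn(CC3OC(n4ccc(=O)[nH]c4=O)C4OC(C)(C)OC34)nn2)n(C)c1=O`: 58200 nM

Both were tested in a functional assay on A-375 cells (Homo sapiens) for cytotoxicity, read by MTT assay, with a stated time of 48 h; a lower number here means a stronger inhibitor, a higher number a weaker inhibitor. Compound 1 gives the lower of the two numbers, and the gap to compound 2 lies beyond the scatter, so compound 1 is the stronger inhibitor of this pair.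

Compound 3 `CCn1c(=O)ccn(C2OC(Cn3cc(COC(=O)C(C)n4cnc5c4c(=O)n(C)c(=O)n5C)nn3)C(O)C2O)c1=O` has not yet been measured. It differs from compound 1 by methyl in place of hydrogen on a saturated chain carbon bound to an aromatic nitrogen and a carbonyl carbon. Going by the values given here, no measured pair shows this change, so its size is unknown; such a small addition is expected to give no step beyond the scatter. Compound 3 is expected near 5000 nM, between 2000 nM and 15000 nM, an expected step of a 1.0-fold higher number from compound 1 to compound 3 (0.01 log units; within the scatter) within the scatter.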

Compound 3, half-maximal inhibitory concentration: 68400 nM
Estimate against measurement, compound 3: 14-fold (1.14 log units) below; the whole stated range lies below it.
By their numbers in this assay, from the lowest: compound 1; then compounds 2 and 3 (each within the scatter of the next).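

In this assay the saturated chain carbon bound to an aromatic nitrogen and a carbonyl carbon proves sensitive: methyl in place of hydrogen, just one added carbon, gives a 14-fold higher number from compound 1 to compound 3 (1.15 log units; beyond the scatter). Even this small addition therefore costs much of the activity of compound 1. Nothing measured here explains the loss.

Still open, as far as these compounds go, is whether an ethyl group or an amine on this carbon would behave the same way. This single pair also cannot show whether the methyl would have a similar effect elsewhere on the chain.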